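The source may hold more compounds than are shown below. What is called first, only, known or untested is meant among the compounds shown, and "the series" means these compounds.

Compound 1 `O=C(CN1CCN(C2CCCCC2)CC1)Nc1nc2c(s1)CCCC2` gives > 10000 nM in an assay on isolated protein for inhibition of long-chain fatty acid transport protein 1 (Mus musculus), read by scintillation counting, with a stated time of 20 min (on this read-out lower numbers stand for stronger inhibition and higher numbers for weaker inhibition), a limit of the assay rather than a number.
Compound 2 `O=C(CN1CCN(c2ccncc2)CC1)Nc1nc2c(s1)CCCC2` gives > 10000 nM in this assay, again a limit.
Compound 3 `O=C(CN1CCN(c2ccc(F)cn2)CC1)Nc1nc2c(s1)CCCC2` gives 600 nM in this assay.

Going by the values given here, compound 3 thus holds the only actual number among the three; the other two sit at the limit of > 10000 nM in this assay, at which 2 of the 3 values shown sit. Exchanging the cyclohexyl of compound 1 for pyridin-4-yl yields a step that the two limits leave unreadable from compound 1 to compound 2, whereas the entry of 5-fluoropyridin-2-yl produces an at least 16-fold lower number from compound 1 to compound 3 (1.22 log units; beyond the scatter) and an at least 16-fold lower number from compound 2 to compound 3 (1.22 log units; beyond the scatter), both large and beyond the scatter.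

Compound 4 `Cc1ccc(N2CCN(CC(=O)Nc3nc4c(s3)CCCC4)CC2)cc1` is not yet measured. It differs from compound 3 by 4-methylphenyl in place of 5-fluoropyridin-2-yl on an amine nitrogen in a ring. Among the compounds with values here, no measured step covers this exact exchange; the only relevant evidence is that a six-membered aromatic ring with a nitrogen bearing fluorine, as in compound 3, gave the sole readable number, while pyridin-4-yl in compound 2 remained at the limit. A carbon-only ring with a methyl keeps an aromatic ring in the position, so compound 4 is expected to retain some activity, but with a weaker result than compound 3, estimated as a 2.5-fold higher number from compound 3 to compound 4 (0.40 log units; beyond the scatter). Compound 4 is therefore expected to give about 1500 nM in this assay, within a range of 400 nM to 10000 nM.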

Compound 4, half-maximal inhibitory concentration: > 10000 nM
Compound 4: a limit, no number; the forecaster's own chance of this, stated with the estimate: 30%; at least 6.6-fold (0.82 log units) between middle value and limit.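

In this assay, putting 4-methylphenyl in place of 5-fluoropyridin-2-yl on the amine nitrogen in the ring gives an at least 16-fold higher number from compound 3 to compound 4 (1.22 log units; beyond the scatter), so at this position the two groups, alike in ring size and heavy-atom count, are far from interchangeable. The steps linking compound 4 to compound 1 and to compound 2 cannot be read, as both ends of each are limits. Among the four compounds, a six-membered aromatic ring on this nitrogen is not enough for a readable number, for compound 2 and compound 4 both carry one and only compound 3 leaves the limit, which now holds most of the series: the limit of > 10000 nM in this assay, at which 3 of the 4 values shown sit.

The step to compound 4 removes the ring nitrogen and exchanges fluorine for methyl at once, so it does not tell which of the two changes counts, or whether both do. Going by these compounds, a 4-fluorophenyl group or an unsubstituted pyridin-2-yl group on this nitrogen would separate the two, and how far a 5-chloropyridin-2-yl or 5-methoxypyridin-2-yl group would keep the number of compound 3 also stays open.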